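A few compounds are considered here, and "the series" means these few. Any claim that something is new, unique, unknown or untested is made for them only; others in the source may bear on it.

Working notes on the cytotoxicity series. Compound 1 `Cc1cccc(C(=O)/C=C/c2ccc([N+](=O)[O-])o2)c1` is the reference point: in an ADME assay on THP-1 cells (Homo sapiens) for cytotoxicity, read by resazurin assay, with a stated time of 72 h (a lower number here means that less compound is tolerated, a higher number that more compound is tolerated), compound 1 gives 42100 nM, the only numeric result in the set. Compound 2 `O=C(/C=C/c1ccc([N+](=O)[O-])o1)c1ccc(N2CCNCC2)cc1` reaches only a limit of the assay, > 50000 nM. Compound 3 `O=C(/C=C/c1ccc([N+](=O)[O-])s1)c1ccc(C2CCCCC2)cc1` likewise gives a limit, > 50000 nM. For the measured compounds named here, compound 1 is therefore the single member with a measured number, and that number lies close to the limit of > 50000 nM in this assay, at which 2 of the 3 values shown sit, so no ordering among the three can be drawn from these data. Going by the values given here, no step between two measured compounds carries the change examined here.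

Compound 4 `O=C(/C=C/c1ccc([N+](=O)[O-])o1)c1cccc(Br)c1` differs from compound 1 by bromo in place of methyl on an aromatic carbon. Among the compounds with values here, with no measured pair bearing this change, the size of the step is unknown; in this assay a step within the scatter is expected, in no particular direction. The estimate for compound 4 is 40000 nM, with a range of 20000 nM to 80000 nM. The step this estimate means is expected to be a 1.1-fold lower number from compound 1 to compound 4 (0.02 log units; within the scatter). A limit rather than a number is also a plausible outcome for compound 4.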

Compound 4, half-maximal cytotoxic concentration: 14900 nM
For compound 4 the middle estimate is 2.7-fold (0.43 log units) above the measured one; the measured number lies below the stated range.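

On the aromatic carbon meta to a large group, the series now has its first readable step: in this assay, bromo in place of methyl gives a 2.8-fold lower number from compound 1 to compound 4 (0.45 log units; beyond the scatter). The result shows that the read-out at this position responds to the group it carries, even though neither group brings a ring, a hydrogen-bond donor or acceptor, or a net charge. Compound 4 also gives a number further from the limit that marks the rest of the set: the limit of > 50000 nM in this assay, at which 2 of the 4 values shown sit.

This single pair cannot show whether the step is particular to bromo or would also appear with chloro, methoxy, an amine or a carboxylic acid on the same carbon. It also leaves open whether bromo in place of methyl would give a similar step elsewhere on the six-membered ring.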